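Predicting Cell Tolerance After a Ring Swap

A few compounds are considered here, and "the series" means these few. Any claim that something is new, unique, unknown or untested is made for them only; others in the source may bear on it.

Compound 1, `NS(=O)(=O)c1ccc(N2N=C(c3ccc(OCc4ccccc4)cc3)CC2c2ccc(Cl)cc2)cc1`: in an ADME assay on MT4 cells (Homo sapiens) for cytotoxicity, read by MTT assay, with a stated time of 96 h (a higher number here means that more compound is tolerated, a lower number that less compound is tolerated), compound 1 gives 70000 nM.
Compound 2, `NS(=O)(=O)c1ccc(N2N=C(c3ccc(OCc4ccccc4)cc3)CC2c2ccccc2F)cc1`: in this assay compound 2 gives 39000 nM.
Compound 3, `NS(=O)(=O)c1ccc(N2N=C(c3ccc(Oc4ccccc4)cc3)CC2c2ccccc2F)cc1`: in this assay compound 3 gives 36000 nM.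

The three measured compounds share one core and differ at two places. From compound 2 to compound 1 the change is 4-chlorophenyl in place of 2-fluorophenyl on a saturated ring carbon, and the step it made is a 1.8-fold higher number from compound 2 to compound 1 (0.25 log units; within the scatter). From compound 2 to compound 3 the step is a 1.1-fold lower number from compound 2 to compound 3 (0.03 log units; within the scatter). Both steps fall within the ordinary scatter of repeated measurements, so the three numbers cannot be told apart in this assay.

Compound 4, `NS(=O)(=O)c1ccc(N2N=C(c3ccc(Oc4ccccc4)cc3)CC2c2ccc(Cl)cc2)cc1`, has not yet been measured in this assay. It differs from compound 3 by 4-chlorophenyl in place of 2-fluorophenyl on a saturated ring carbon. Within the data shown here, this is the same change as the one from compound 2 to compound 1, and its surroundings read word for word alike, so it is the same change made on a different core. The two cores themselves differ by phenyl in place of benzyl on an oxygen on an aromatic ring.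

Compound 4 is expected to move from compound 3 by a 1.7-fold higher number from compound 3 to compound 4 (0.22 log units; within the scatter), because the earlier step of a 1.8-fold higher number from compound 2 to compound 1 (0.25 log units; within the scatter) was within the scatter and gives no reason to expect a large shift. Compound 4 is therefore estimated at 60000 nM, with a likely range from 30000 nM to 120000 nM. Among the measured compounds shown here, this rests on only one prior example of the change, so the expectation is loose.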

Compound 4, half-maximal cytotoxic concentration: 9000 nM
Beside the measured number, compound 4's estimate is 6.7-fold (0.82 log units) above it, and the stated range ends above it.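

In this assay, putting 4-chlorophenyl in place of 2-fluorophenyl gave a 4.0-fold lower number from compound 3 to compound 4 (0.60 log units; beyond the scatter), so this change did not carry over from the core of compound 2 to the core of compound 3: the same change on two cores in this assay, a 1.8-fold higher number (0.25 log units; within the scatter) from compound 2 to compound 1 and a 4.0-fold lower number (0.60 log units; beyond the scatter) from compound 3 to compound 4, 7.2-fold (0.86 log units) apart, beyond the scatter of two such steps

Read along the other direction, phenyl in place of benzyl on the oxygen gave a 7.8-fold lower number from compound 1 to compound 4 (0.89 log units; beyond the scatter), which shows that the outcome of each change depends on the group present at the other place: the same change on two cores in this assay, a 1.1-fold lower number (0.03 log units; within the scatter) from compound 2 to compound 3 and a 7.8-fold lower number (0.89 log units; beyond the scatter) from compound 1 to compound 4, 7.2-fold (0.86 log units) apart, beyond the scatter of two such steps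

In this series, then, the effects of the two changes on cell tolerance cannot simply be added together, but this rests on a single set of four compounds and does not show why the two changes interact.

The compounds shown leave open whether the lower number of compound 4 follows the chlorine itself or its place on the ring, a question that a 2-chlorophenyl or a 4-fluorophenyl group on the same saturated ring carbon could help to settle. Going by these compounds, it also remains open whether a longer chain on the oxygen, such as phenylethyl, would follow the pattern of the benzyl compounds or that of the phenyl compounds.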